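The compounds below may be only part of what the source reports. "The series", "measured", "known", "first", "only" and "open" are said of these compounds alone.

Compound 1 `CCOc1ccccc1-c1ccc(-c2nc(NC(C)C(=O)O)c3ccncc3n2)cc1`: 2.1
Compound 2 `CC[C@@H](Nc1c(C#N)c(-c2ccc(-c3ccc(F)cc3)cc2)nc2cnccc12)C(N)=O`: 2.7
Compound 3 `CCOc1ccccc1-c1ccc(-c2nc3cnccc3c(N[C@H](CC(C)C)C(N)=O)c2C#N)cc1`: 3.4

Three compounds have a number in a physicochemical assay for lipophilicity, read by HPLC, at pH 7.5; on this read-out lower numbers stand for lower lipophilicity and higher numbers for higher lipophilicity. Among them compound 2 stands second highest: its nearest neighbour is compound 1, whose value in this assay, 2.1, lies lower by a margin beyond the scatter, and the furthest is compound 3, whose value, 3.4, lies higher, again beyond the scatter. Compound 2 itself gives 2.7.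

Compound 4 `CC[C@@H](Nc1c(C#N)c(-c2ccc(-c3ccccc3C)cc2)nc2cnccc12)C(N)=O` has not yet been measured in this assay. It differs from compound 2 in one place: 2-methylphenyl in place of 4-fluorophenyl on an aromatic carbon. Going by the values given here, no pair of measured compounds shows this exchange, so the size of the step rests on no measured precedent. A small upward step from compound 2 to compound 4 is expected, of a size at the edge of the usual scatter, a number 0.30 log units higher from compound 2 to compound 4 (within the scatter). On that basis compound 4 is estimated at 3 in this assay, with a range from 2.6 to 3.4.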

Compound 4, distribution coefficient: 3
Compound 4: middle estimate and measured number agree at the digits printed; low and high end bracket the measured number.
By their numbers in this assay, from the lowest: compound 1; then compounds 2 and 4 (each within the scatter of the next); then compound 3.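

Going by these compounds alone, compound 2 and compound 4 form the first pair in the set that differs in one place, so this position can now be read directly. In this assay, 2-methylphenyl in place of 4-fluorophenyl on an aromatic carbon, para to a large group, gives a number 0.30 log units higher from compound 2 to compound 4 (within the scatter), so this read-out does not separate the two compounds, although the exchange replaces the fluorine with carbon while keeping the heavy-atom count. No measurement shown here speaks to why the two groups read alike.

As far as these compounds go, whether an amine or a carboxylic acid on this ring, or a longer chain in place of the methyl, would carry the number beyond the scatter remains open. One pair also cannot show whether the same exchange would give a similar step with a different side chain on the shared core.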